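The source may report more compounds than this note shows. Statements on the series, on what has been measured and on what is new or still open speak of the compounds shown alone.

Of the compounds shown here, three that share one core have been tested in an assay on MDA-MB-231 cells for binding affinity to C-X-C chemokine receptor type 4 (Homo sapiens), read by immunofluorescence and microscopy, with stated times of 10 min and 30 min; a lower number here means that less compound is needed, a higher number that more compound is needed for the effect. Compound 1 `Cc1ccc(S(=O)(=O)NCc2ccc(CNC(=O)c3ccncc3)cc2)cc1` gives 10 nM. Compound 2 `Cc1ccc(S(=O)(=O)NCc2ccc(CNC(=O)c3ccc(Cl)cc3)cc2)cc1` gives 10 nM. Compound 3 `Cc1ccc(S(=O)(=O)NCc2ccc(CNC(=O)c3cccc(F)c3)cc2)cc1` gives 1 nM. The step of no change at the digits printed from compound 1 to compound 2 (within the scatter) shows that the pyridin-4-yl and 4-chlorophenyl groups on the carbonyl carbon cannot be told apart on these numbers. The steps of a 10-fold lower number from compound 1 to compound 3 (1.00 log units; beyond the scatter) and a 10-fold lower number from compound 2 to compound 3 (1.00 log units; beyond the scatter) are both beyond the scatter, so compound 3 stands lowest of the three, with compound 1 and compound 2 clearly above it.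

Compound 4 `Cc1ccc(S(=O)(=O)NCc2ccc(CNC(=O)c3cccc(C)c3)cc2)cc1` differs from compound 3 by methyl in place of fluoro on an aromatic carbon. Going by the values given here, no measured pair tests a methyl against a fluoro; the measured steps all exchange the whole aryl group on the carbonyl carbon. What they show is that a 3-fluorophenyl gives the lowest number of the three, while the pyridin-4-yl and 4-chlorophenyl give equal numbers above it. Compound 4 keeps a phenyl carrying its single substituent in the same position, and the step of a 2.0-fold higher number from compound 3 to compound 4 (0.30 log units; within the scatter) is therefore expected to stay within the scatter, with a slight lean toward a higher number only because compound 3 gives 1 nM as the best value seen, and that value has no partner to confirm it. Compound 4 is estimated at 2 nM, with a range from 0.7 nM to 6 nM.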

Compound 4, effective concentration (reported as EC, without a stated level of effect): 1000 nM
Estimate against measurement, compound 4: 500-fold (2.70 log units) below, and the stated range ends below it.
By their numbers in this assay, from the lowest: compound 3; then compounds 1 and 2 (each within the scatter of the next); then compound 4.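

In this assay, methyl in place of fluoro on an aromatic carbon, meta to a large group, exchanges one heavy atom for one heavy atom with no change in the counted hydrogen-bond donors, hydrogen-bond acceptors or net charge, yet it gives a 1000-fold higher number from compound 3 to compound 4 (3.00 log units; beyond the scatter), so this substituent weighs far more than the earlier exchanges of the whole aryl group could show. Going by these compounds alone, the 3-methylphenyl group also separates clearly from the two groups that could not be told apart, with a 100-fold higher number from compound 2 to compound 4 (2.00 log units; beyond the scatter) and a 100-fold higher number from compound 1 to compound 4 (2.00 log units; beyond the scatter), so a single small substituent here moves the number further than any exchange among the earlier compounds. Nothing given here bears on what lies behind the gap between fluoro and methyl at this position.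

As far as these compounds go, with only fluoro and methyl to compare at this place, it remains open whether an unsubstituted phenyl, a chloro, a methoxy or a hydroxy group would fall near compound 3 or near compound 4. From the compounds shown here alone, it is also open whether the same gap would persist with fluoro and methyl elsewhere on the ring, as in a 4-fluorophenyl and a 4-methylphenyl pair.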